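Dropping the methoxy from compound 2

This account rests on a few compounds, and the source may have more. Where it says the series, first, only, none or still open, it means among the compounds named here.

In a functional assay on A549 cells (Homo sapiens) for inhibition, read by sulforhodamine B assay, with a stated time of 72 h (on this read-out higher numbers stand for weaker inhibition and lower numbers for stronger inhibition), compound 1 `Nc1sc(-c2ccc(Cl)cc2)c(-c2ccc(Cl)cc2)c1C(=O)N1CCCCC1` gives 4620 nM, and compound 2 `COc1ccc(CNC(=O)c2c(N)sc(-c3ccc(Cl)cc3)c2-c2ccc(Cl)cc2)cc1` gives 18200 nM, the higher of the two numbers and so the weaker inhibition. Among the measured compounds shown here, the only measured step, a 3.9-fold higher number from compound 1 to compound 2 (0.60 log units; beyond the scatter), puts (4-methoxybenzyl)amino in place of piperidin-1-yl. Compound 3 `Nc1sc(-c2ccc(Cl)cc2)c(-c2ccc(Cl)cc2)c1C(=O)NCc1ccccc1` differs from compound 2 at one place: hydrogen in place of methoxy on an aromatic carbon. For the measured compounds named here, no measured step touches the methoxy itself, so in this assay no shift beyond the scatter is expected. The estimated step is a 1.3-fold lower number from compound 2 to compound 3 (0.11 log units; within the scatter). Compound 3 is estimated at 14000 nM, with an expected range from 5000 nM to 35000 nM.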

Compound 3, half-maximal inhibitory concentration: 16300 nM
Compound 3: the middle estimate sits 1.2-fold (0.07 log units) below what was measured; measured number inside the range.
By their numbers in this assay, from the lowest: compound 1; then compounds 3 and 2 (each within the scatter of the next).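

In this assay the methoxy on the aromatic ring carries no weight that can be read (a 1.1-fold lower number from compound 2 to compound 3 (0.05 log units; within the scatter)). The benzylamino amide also stays apart from the piperidin-1-yl amide of compound 1 (a 3.5-fold higher number from compound 1 to compound 3 (0.55 log units; beyond the scatter)), so that gap does not depend on the methoxy. No measured evidence explains either step.

The compounds shown leave open whether a hydroxyl, an amine or a carboxylic acid on this ring carbon would also go unnoticed. They also leave open whether a longer chain between the amide nitrogen and the ring would matter.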